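Opening the Protected Piperidine: From Compound 3 to Compound 4

A few compounds are considered here, and "the series" means these few. Any claim that something is new, unique, unknown or untested is made for them only; others in the source may bear on it.

Compound 3 `CC(=O)NC1CCN(c2nc3c(c(Nc4ccc(C(F)(F)F)cc4)n2)CCN(c2ncccc2C(F)(F)F)CC3)C1` gives 410 nM in a functional assay on HEK293 cells for antagonist activity at transient receptor potential cation channel subfamily V member 1 (Rattus norvegicus), read by FLIPR and calcium flux (on this read-out higher numbers stand for weaker inhibition and lower numbers for stronger inhibition), and compound 1 `CC(C)(C)OC(=O)N1CCCC(Nc2nc3c(c(Nc4ccc(C(F)(F)F)cc4)n2)CCN(c2ncccc2C(F)(F)F)CC3)C1` gives 239 nM, the two numbers lying within the scatter of each other. Compound 2 `CNC1CCN(c2nc3c(c(Nc4ccc(C(F)(F)F)cc4)n2)CCN(c2ncccc2C(F)(F)F)CC3)C1` reaches only the limit of > 5000 nM in this assay. Putting acetyl in place of methyl on that amine nitrogen gives an at least 12-fold lower number from compound 2 to compound 3 (1.08 log units; beyond the scatter). Compound 4 `FC(F)(F)c1ccc(Nc2nc(NC3CCCNC3)nc3c2CCN(c2ncccc2C(F)(F)F)CC3)cc1` differs from compound 3 by (piperidin-3-yl)amino in place of 3-acetamidopyrrolidin-1-yl on an aromatic carbon. Within the data shown here, no measured step matches this change directly; compound 1 carries a protected form of the same piperidine, while compound 2, with a free secondary amine, sits at the limit (the limit of > 5000 nM in this assay, at which 1 of the 3 values shown sits). Compound 4 is therefore expected to give a weaker number, estimated at 2000 nM (range 500 nM to 8000 nM), a step of a 4.9-fold higher number from compound 3 to compound 4 (0.69 log units; beyond the scatter).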

Compound 4, half-maximal inhibitory concentration in the transient receptor potential cation channel subfamily V member 1 assay: > 5000 nM
Compound 4 was reported as a limit; the forecaster's own chance of this, stated with the estimate: 30%; at least 2.5-fold (0.39 log units) between middle value and limit.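

In the transient receptor potential cation channel subfamily V member 1 assay compound 4 gives > 5000 nM as a limit of the assay. In the transient receptor potential cation channel subfamily V member 1 assay, the change on the aromatic carbon gives an at least 12-fold higher number from compound 3 to compound 4 (1.08 log units; beyond the scatter), and hydrogen in place of tert-butoxycarbonyl on the ring nitrogen gives an at least 20-fold higher number from compound 1 to compound 4 (1.32 log units; beyond the scatter). A carbonyl on the amine nitrogen therefore goes with a readable number in compound 1 and compound 3, whether the ring is the piperidine or the pyrrolidine. Compound 2 and compound 4, both with a free secondary amine, stand at a limit, so the step between them cannot be read: the limit of > 5000 nM in the transient receptor potential cation channel subfamily V member 1 assay, at which 2 of the 4 values shown sit.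

In a physicochemical assay for solubility, in phosphate buffer, measured as thermodynamic solubility, at pH 2 (on this read-out higher numbers stand for higher solubility and lower numbers for lower solubility), compound 3 gives 202 ug/mL as its value. In the physicochemical assay compound 4 gives > 235 ug/mL as a limit of the assay: the limit of > 235 ug/mL in the physicochemical assay, at which 1 of the 2 values shown sits.

Still open, going by these compounds, is whether a methanesulfonyl group on the piperidine nitrogen would give a readable number. Also open, on these data alone, is whether an acetyl on that nitrogen would match compound 1.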